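Swapping the 4-bromobenzyl group of compound 3

A few compounds are considered here, and "the series" means these few. Any claim that something is new, unique, unknown or untested is made for them only; others in the source may bear on it.

Compound 1 `COc1ccc(CN(C(=O)CSC(=S)N2CCc3cc(Br)ccc32)c2cc(OC)c(OC)c(OC)c2)cc1`: > 20000 nM, a limit
Compound 2 `COc1ccc(CN(C(=O)CSC(=S)N2CCc3ccccc3C2)c2cc(OC)c(OC)c(OC)c2)cc1`: > 20000 nM, a limit
Compound 3 `COc1cc(N(Cc2ccc(Br)cc2)C(=O)CSC(=S)N2CCN(C(=O)OC(C)(C)C)CC2)cc(OC)c1OC`: 10700 nM

Going by the values given here, in a functional assay on KYSE-450 cells (Homo sapiens) for inhibition, read by CCK-8 assay, with a stated time of 48 h (a higher number here means a weaker inhibitor, a lower number a stronger inhibitor), compound 3 gives 10700 nM, the only actual number in the set. The other two values are limits: the limit of > 20000 nM in this assay, at which 2 of the 3 values shown sit. Compound 4 `COc1ccc(CN(C(=O)CSC(=S)N2CCN(C(=O)OC(C)(C)C)CC2)c2cc(OC)c(OC)c(OC)c2)cc1C` is the next to be read. The change is 4-methoxy-3-methylphenyl in place of 4-bromophenyl on a saturated chain carbon bound to an amide-type nitrogen, that is, 4-bromobenzyl to 4-methoxy-3-methylbenzyl. Among the compounds with values here, the single measured step, a step that the two limits leave unreadable from compound 1 to compound 2, sits at a different place and gives no size, so no measured step scales this change. The expectation therefore starts from compound 3 at 10700 nM, with a small move toward stronger inhibition that stays within the scatter. The expected step is a 1.8-fold lower number from compound 3 to compound 4 (0.25 log units; within the scatter). For compound 4 the estimate is 6000 nM, with an expected range of 500 nM to 20000 nM.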

Compound 4, half-maximal inhibitory concentration: > 20000 nM
Compound 4 was reported as a limit (the forecaster's own chance of this, stated with the estimate: 20%); middle value at least 3.3-fold (0.52 log units) from the limit.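

In this assay, this position on the saturated chain carbon bound to the amide-type nitrogen now has its first readable step: 4-methoxy-3-methylbenzyl in place of 4-bromobenzyl gives an at least 1.8-fold higher number from compound 3 to compound 4 (0.27 log units; that floor lies within the scatter). The floor of that step does not separate the two groups, so no loss beyond the scatter is established. Compound 3 remains the only compound with an actual number, and the rest of the set sits at one limit: the limit of > 20000 nM in this assay, at which 3 of the 4 values shown sit.

From the compounds shown here alone, the true size of the step stays open, and the step from compound 1 to compound 2 still cannot be read. Also open, going by these compounds, is what a benzyl group carrying an amine or a carboxylic acid would give at this position.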